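Adding 4-fluorobenzyl to compound 3

This account rests on a few compounds, and the source may have more. Where it says the series, first, only, none or still open, it means among the compounds named here.

compound 1 `COc1ccc(-n2c(S)nnc2-c2cc(OC)c(OC)c(OC)c2)cc1`: 57500 nM
compound 2 `COc1ccc(-n2c(SCC(=O)c3ccc(OC)c(O)c3)nnc2-c2cc(OC)c(OC)c(OC)c2)cc1`: > 60000 nM, a limit
compound 3 `COc1cc(-c2nnc(S)n2-c2ccc(N(C)C)cc2)cc(OC)c1OC`: > 60000 nM, a limit

All three compounds were tested in a functional assay on HepG2 cells (Homo sapiens) for inhibition, read by MTT assay, with a stated time of 48 h; on this read-out lower numbers stand for stronger inhibition and higher numbers for weaker inhibition. Compound 3 stands at the limit of > 60000 nM in this assay, at which 2 of the 3 values shown sit, so it has a limit and no exact number. Compound 4 `COc1cc(-c2nnc(SCc3ccc(F)cc3)n2-c2ccc(N(C)C)cc2)cc(OC)c1OC` carries 4-fluorobenzyl in place of hydrogen on a sulfur.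

For the measured compounds named here, two measured steps bear on this change. One also adds a group on a sulfur: an at least 1.0-fold higher number from compound 1 to compound 2 (0.01 log units; that floor lies within the scatter). The other swaps methoxy for dimethylamino: an at least 1.0-fold higher number from compound 1 to compound 3 (0.01 log units; that floor lies within the scatter). Both are only floors within the scatter, so neither shows a real shift in either direction.

No step beyond the scatter is expected, and the estimated step is an at least 1.2-fold lower number from compound 3 to compound 4 (0.07 log units; that floor lies within the scatter). The result may again be only a limit. For compound 4 the expected value is 50000 nM, with an estimated range from 12000 nM to 100000 nM.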

Compound 4, half-maximal inhibitory concentration: 26400 nM
Estimate against measurement, compound 4: 1.9-fold (0.28 log units) above; the range from low to high includes it.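

In this assay, 4-fluorobenzyl in place of hydrogen on a sulfur gives an at least 2.2-fold lower number from compound 3 to compound 4 (0.35 log units; beyond the scatter) and is the first step among these compounds to lie beyond the scatter. The earlier step that added a different group on a sulfur, from compound 1 to compound 2, remained a floor within the scatter. On these data alone, the true size of the new step stays unknown, as compound 3 has only a limit: the limit of > 60000 nM in this assay, at which 2 of the 4 values shown sit.

Open, as far as these compounds go, is whether the fluorine matters, or whether plain benzyl, methyl or a longer chain carrying an amine on this sulfur would do the same. Also open, from the compounds shown here alone, is whether 4-fluorobenzyl has the same effect on compound 1, which carries methoxy in place of dimethylamino.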